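This account rests on a few compounds, and the source may have more. Where it says the series, first, only, none or still open, it means among the compounds named here.

Measured so far:
compound 1 `CC(=O)c1ccc(OCc2cccc([N+](=O)[O-])c2)cc1`: 51300 nM
compound 2 `CC(=O)c1ccc(OCc2ccccc2Cl)cc1`: 89600 nM

In an assay on isolated protein for inhibition of Amine oxidase [flavin-containing] A (Homo sapiens), read by Amplex Red, with a stated time of 15 min (on this read-out higher numbers stand for weaker inhibition and lower numbers for stronger inhibition), compound 2 gives 89600 nM. In this assay compound 1 gives 51300 nM, and these two values lie within the usual scatter of each other, so neither stands apart. Compound 3 `CC(=O)c1ccc(OCc2ccccc2C(F)(F)F)cc1` differs from compound 2 in one place: trifluoromethyl in place of chloro on an aromatic carbon. Going by the values given here, no comparable step has been measured, so the step expected here is a 1.1-fold lower number from compound 2 to compound 3 (0.05 log units; within the scatter), which is no change beyond the scatter. Compound 3 is therefore estimated at 80000 nM, with a range from 30000 nM to 200000 nM.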

Compound 3, half-maximal inhibitory concentration: 70500 nM
Compound 3: the middle estimate sits 1.1-fold (0.05 log units) above what was measured; the measured number falls inside the stated range.
By their numbers in this assay, from the lowest: compounds 1, 3 and 2 (each within the scatter of the next).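

In this assay, putting trifluoromethyl, a group of 4 heavy atoms, in place of the single chlorine on this aromatic carbon gives a 1.3-fold lower number from compound 2 to compound 3 (0.10 log units; within the scatter) and so leaves the reading within the scatter. This position therefore tolerates either group, and the extra heavy atoms bring no measurable gain or loss in inhibition. No separate measurement bears on why the two groups read alike.

Going by these compounds, whether an amine or a carboxylic acid at this same position would shift the number remains open. So does whether the same exchange would behave alike elsewhere on the shared core.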